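Replacing 4H-1,2,4-triazol-3-yl with 2-oxoimidazolidin-1-yl

The compounds below may be only part of what the source reports. "The series", "measured", "known", "first", "only" and "open" are said of these compounds alone.

- Compound 1 `CCn1ncc2c(F)cc(-c3ccc(C(CC)(CC)c4nnc[nH]4)c(=O)[nH]3)cc21` gives 2.7 h
- Compound 2 `CC(C)C(c1ccc(-c2ccc3cccc(F)c3c2)[nH]c1=O)N1CCN/C1=N\C#N` gives 0.632 h
- Compound 3 `CC(C)C(c1nnc[nH]1)c1ccc(-c2ccc3cccc(F)c3c2)[nH]c1=O` gives 0.905 h

These values come from an ADME assay on microsomes from liver (Homo sapiens) for metabolic stability (a lower number here means that the compound disappears faster, a higher number that the compound lasts longer), and are read as half-lives. Compound 3 lies within the usual scatter of compound 2 and clearly lower than compound 1. Compound 4 `CC(C)C(c1ccc(-c2ccc3cccc(F)c3c2)[nH]c1=O)N1CCNC1=O` differs from compound 3 by 2-oxoimidazolidin-1-yl in place of 4H-1,2,4-triazol-3-yl on a saturated chain carbon bound to an aromatic carbon and a saturated chain carbon and now carries a five-membered non-aromatic ring with 2 hetero atoms. Among the compounds with values here, the one measured step at this place is a 1.4-fold higher number from compound 2 to compound 3 (0.16 log units; within the scatter), which links a ring of that description with the 4H-1,2,4-triazol-3-yl group. A step of that size points to no expected change beyond the scatter. For compound 4, the expected step in this assay is a 1.1-fold lower number from compound 3 to compound 4 (0.05 log units; within the scatter). Compound 4 is estimated at 0.8 h, with an expected range of 0.4 h to 1.6 h.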

Compound 4, half-life: 1.03 h
Compound 4: the middle estimate sits 1.3-fold (0.11 log units) below what was measured, and the stated range covers the measured number.
By their numbers in this assay, from the lowest: compounds 2, 3 and 4 (each within the scatter of the next); then compound 1.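

In this assay the place on the saturated chain carbon has now held three groups without a step beyond the usual scatter: a 1.1-fold higher number from compound 3 to compound 4 (0.06 log units; within the scatter) and a 1.6-fold higher number from compound 2 to compound 4 (0.21 log units; within the scatter) both stay within it. The half-life therefore does not separate 2-oxoimidazolidin-1-yl from 4H-1,2,4-triazol-3-yl, although one ring is aromatic and the other is not. No measurement here offers a reason for this. From the compounds shown here alone, whether an open-chain group at this place, such as an amine or a carboxylic acid, would give a step beyond the scatter remains open.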